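The source may report more compounds than this note shows. Statements on the series, on what has been measured and on what is new or still open speak of the compounds shown alone.

Notes on the series. The shared core is varied only at the aryl on a carbon with a double bond to nitrogen. In a functional assay on A549 cells (Homo sapiens) for cytotoxicity, read by MTT assay, with a stated time of 72 h (a higher number here means a weaker inhibitor, a lower number a stronger inhibitor), compound 1 `CN(C)CCn1cnnc1-c1cc(Oc2ccc(NC(=O)N/N=C/c3ccc(Cl)cc3Cl)cc2F)ccn1` gives 810 nM and compound 2 `CN(C)CCn1cnnc1-c1cc(Oc2ccc(NC(=O)N/N=C/c3ccccc3)cc2F)ccn1` gives 1860 nM, the step between them being a 2.3-fold higher number from compound 1 to compound 2 (0.36 log units; beyond the scatter). Compound 3 `CN(C)CCn1cnnc1-c1cc(Oc2ccc(NC(=O)N/N=C/c3cc(Br)c(O)c(Br)c3)cc2F)ccn1` reports only a limit, > 100000 nM, and stands at the limit of > 100000 nM in this assay, at which 1 of the 3 values shown sits. The measured steps onto compound 3 were an at least 120-fold higher number from compound 1 to compound 3 (2.09 log units; beyond the scatter) and an at least 53-fold higher number from compound 2 to compound 3 (1.73 log units; beyond the scatter). Compound 4 `CN(C)CCn1cnnc1-c1cc(Oc2ccc(NC(=O)N/N=C/c3cccc(O)c3)cc2F)ccn1` differs from compound 3 by 3-hydroxyphenyl in place of 3,5-dibromo-4-hydroxyphenyl on a carbon with a double bond to nitrogen. Both large measured steps accompanied bringing in the 3,5-dibromo-4-hydroxyphenyl; taking it out is expected to reverse most of that, and the expected step is an at least 33-fold lower number from compound 3 to compound 4 (1.52 log units; beyond the scatter). A number near that of compound 2, 1860 nM, seems the likeliest landing. Compound 4 is therefore estimated at 3000 nM, within 900 nM to 20000 nM.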

Compound 4, half-maximal inhibitory concentration: > 100000 nM
Compound 4 was reported as a limit (the forecaster's own chance of this, stated with the estimate: 20%); middle value at least 33-fold (1.52 log units) away from the limit.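

Without the bromine atoms of compound 3, activity does not return in this assay, and the step between these two compounds cannot be read. The hydroxy-bearing aryl alone accompanies the loss, with an at least 53-fold higher number from compound 2 to compound 4 (1.73 log units; beyond the scatter) and an at least 120-fold higher number from compound 1 to compound 4 (2.09 log units; beyond the scatter). Compound 3 and compound 4 both report only a limit: the limit of > 100000 nM in this assay, at which 2 of the 4 values shown sit.

Open, on these data alone, is whether the hydroxy itself goes with the loss or other groups on this aryl would do the same, which a methoxy or an amine in its place would test. As far as these compounds go, how far compound 3 and compound 4 lie past the limit also stays open.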